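Tetrahydroisoquinoline in Place of a Hydroxyethyl Piperidine

A few compounds are considered here, and "the series" means these few. Any claim that something is new, unique, unknown or untested is made for them only; others in the source may bear on it.

Measured compounds:
compound 1 `COc1cc2c(Nc3ccc(C#N)cc3)ncnc2cc1OCCCN1CCCCC1`: 18800 nM
compound 2 `COc1cc2c(Nc3ccc(C#N)cc3)ncnc2cc1OCCCN1CCCCC1CCO`: > 100000 nM

In a functional assay on SH-SY5Y cells (Homo sapiens) for antiproliferative activity, read by MTT assay, with a stated time of 72 h (on this read-out lower numbers stand for stronger inhibition and higher numbers for weaker inhibition), compound 1 gives 18800 nM. Compound 2 reaches only a limit of the assay, > 100000 nM, which is the limit of > 100000 nM in this assay, at which 1 of the 2 values shown sits. For the measured compounds named here, the one measured step, an at least 5.3-fold higher number from compound 1 to compound 2 (0.72 log units; beyond the scatter), came from adding a hydroxyethyl group. Compound 3 `COc1cc2c(Nc3ccc(C#N)cc3)ncnc2cc1OCCCN1CCc2ccccc2C1` differs from compound 2 by 1,2,3,4-tetrahydroisoquinolin-2-yl in place of 2-(2-hydroxyethyl)piperidin-1-yl on a saturated chain carbon, three bonds along the chain from an oxygen on an aromatic ring. Since compound 2 sits at a limit, the true size of the next step is uncertain; the amine ring is retained but the hydroxyethyl is gone. Compound 3 is therefore expected to return toward the range of compound 1, estimated at 25000 nM, between 8000 nM and 90000 nM. This corresponds to an expected step of an at least 4.0-fold lower number from compound 2 to compound 3 (0.60 log units; beyond the scatter).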

Compound 3, half-maximal inhibitory concentration: > 100000 nM
Compound 3: only a limit was reported (the forecaster's own chance of this, stated with the estimate: 25%); at least 4.0-fold (0.60 log units) between middle value and limit.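

Replacing the piperidin-1-yl of compound 1 with 1,2,3,4-tetrahydroisoquinolin-2-yl gives an at least 5.3-fold higher number from compound 1 to compound 3 (0.72 log units; beyond the scatter) in this assay. A second change to the amine ring, this one without a hydroxyethyl group, therefore also gives a weaker result than compound 1. The step between compound 2 and compound 3 cannot be read, because each of them gives only a limit: the limit of > 100000 nM in this assay, at which 2 of the 3 values shown sit.

Going by these compounds, how weak compound 2 and compound 3 truly are stays open. So does whether a morpholine ring or a dimethylamino group at this place would give a lower number than compound 1.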